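The compounds below may be only part of what the source reports. "The series", "measured", "known", "first", "only" and "open" are said of these compounds alone.

In an ADME assay on NIH3T3 cells (Mus musculus) for cytotoxicity (on this read-out higher numbers stand for an effect only at larger amounts of compound and lower numbers for an effect already at smaller amounts), three compounds have been measured. Compound 1 `c1ccc(Oc2cccc(Cn3ccnc3)c2)cc1` gives > 100000 nM, and this value is a limit of the assay, not a number. Compound 2 `Cc1cc(Oc2cccc(Cn3cncn3)c2)cc(C)c1Cl` gives 75900 nM, and compound 3 `Cc1cc(Oc2cccc(Cn3cnc4ccccc43)c2)cc(C)c1Cl` gives 40000 nM. These two numbers lie within the usual scatter of each other, so compound 2 stands level with compound 3 and the data do not separate them.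

Compound 4 `Cc1nnc(Cc2cccc(Oc3cc(C)c(Cl)c(C)c3)c2)s1` has not yet been measured. It differs from compound 2 in one place: 5-methyl-1,3,4-thiadiazol-2-yl in place of 1H-1,2,4-triazol-1-yl on a saturated chain carbon bound to an aromatic carbon. The 5-methyl-1,3,4-thiadiazol-2-yl stands in place of the 1H-1,2,4-triazol-1-yl on a saturated chain carbon bound to an aromatic carbon, and each is one five-membered aromatic ring with 3 hetero atoms and no net charge.

Going by the values given here, no measured pair shows this change on its own, so the expectation rests on a looser comparison. Compound 3, which carries a different group at this place, gives 40000 nM, within the scatter of compound 2. A change of group here is therefore not expected to move the number much. The expected step is a 1.4-fold lower number from compound 2 to compound 4 (0.14 log units; within the scatter), a slight fall that is estimated to stay within the scatter. Compound 4 is estimated at 55000 nM, with an expected range from 25000 nM to 100000 nM.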

Compound 4, half-maximal effective concentration: 3800 nM
Beside the measured number, compound 4's estimate is 14-fold (1.16 log units) above it, outside the stated range (below it).
By their numbers in this assay, from the lowest: compound 4; then compounds 3 and 2 (each within the scatter of the next). At a limit, above all of these: compound 1.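

In this assay, the place on a saturated chain carbon bound to an aromatic carbon proves sensitive to the group it carries: 5-methyl-1,3,4-thiadiazol-2-yl in place of 1H-1,2,4-triazol-1-yl gives a 20-fold lower number from compound 2 to compound 4 (1.30 log units; beyond the scatter). The two groups match in ring type, in hydrogen-bond donors and acceptors, and in net charge, so these shared counts do not account for the step, which goes with what differs: the sulfur, the carbon and nitrogen counts, and the extra heavy atom. Both ends of this step are numbers rather than limits, and the only value at a limit is that of compound 1: the limit of > 100000 nM in this assay, at which 1 of the 4 values shown sits.

The change brings in the sulfur-containing ring and the methyl together, so the compounds shown cannot divide the step between them. As far as these compounds go, how a 1,3,4-thiadiazol-2-yl without the methyl, a 5-methyl-1,3,4-oxadiazol-2-yl or an amine would read at this place remains open, as does whether the same change would have a similar effect on the core of compound 1.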